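The source may report more compounds than this note shows. Statements on the series, on what has been measured and on what is new or still open speak of the compounds shown alone.

Measured so far:
- compound 1 `N#CC1=C(N)N(c2ccc(S(N)(=O)=O)cc2)C2=C(CCCC2)C1c1ccc([N+](=O)[O-])cc1`: > 100 ug/mL
- compound 2 `COc1ccc2ccccc2c1C1C(C#N)=C(N)N(c2ccc(S(N)(=O)=O)cc2)C2=C1CCCC2`: 100 ug/mL

Of the compounds shown here, two have been tested in a functional assay on Ehrlich cells (Mus musculus) for cytotoxicity, read by trypan blue exclusion, with a stated time of 2 h; on this read-out higher numbers stand for weaker inhibition and lower numbers for stronger inhibition. Compound 1 `N#CC1=C(N)N(c2ccc(S(N)(=O)=O)cc2)C2=C(CCCC2)C1c1ccc([N+](=O)[O-])cc1` gives > 100 ug/mL; this is a limit of the assay and not a number, and compound 1 sits at the limit of > 100 ug/mL in this assay, at which 1 of the 2 values shown sits. Compound 2 `COc1ccc2ccccc2c1C1C(C#N)=C(N)N(c2ccc(S(N)(=O)=O)cc2)C2=C1CCCC2` gives 100 ug/mL. Among the compounds with values here, with one value being a limit, the two compounds show no difference that can be stated as a step, and no step between measured compounds is available to set a scale for the series.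

Compound 3 `Cc1ccc(C2C(C#N)=C(N)N(c3ccc(S(N)(=O)=O)cc3)C3=C2CCCC3)o1` differs from compound 1 in one place: 5-methylfuran-2-yl in place of 4-nitrophenyl on a saturated ring carbon of the shared core. The step from compound 1 to compound 3 in this assay is expected to be none beyond the scatter, since both measured compounds sit at or at the edge of the assay ceiling. Compound 3 is therefore estimated at 100 ug/mL, with a range from 50 ug/mL to 200 ug/mL, and the step this estimate means is a number no higher from compound 1 to compound 3 (the limit leaves the size open); a limit rather than a number is expected to be a likely outcome for compound 3.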

Compound 3, half-maximal inhibitory concentration: > 100 ug/mL
Compound 3: only a limit was reported; the forecaster's own chance of this, stated with the estimate: 55%; the middle value lies on the limit itself.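

In this assay compound 3 gives > 100 ug/mL, which is a limit of the assay and not a number. Compound 1 also stands at a limit, and no step can be read between compound 1 and compound 3: the limit of > 100 ug/mL in this assay, at which 2 of the 3 values shown sit. The compounds shown leave open how large the change from 4-nitrophenyl to 5-methylfuran-2-yl is, and in which direction it runs.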